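Chalcone series: halogen swap at the aryl ketone

The source may report more compounds than this note shows. Statements on the series, on what has been measured and on what is new or still open speak of the compounds shown alone.

Measured so far:
- compound 1 `O=C(/C=C/c1cccc(OCc2ccccc2)c1)c1ccc(Br)cc1`: 6500 nM
- compound 2 `O=C(/C=C/c1cccc(OCc2ccccc2)c1)c1ccc([N+](=O)[O-])cc1`: 37700 nM

Two compounds of the series have numbers in a functional assay on ZR-75-1 cells (Homo sapiens) for cytotoxicity, read by MTT assay, with a stated time of 68 h; on this read-out higher numbers stand for weaker inhibition and lower numbers for stronger inhibition. For the measured compounds named here, compound 1 gives the lower of the two, and in this assay compound 2 gives 37700 nM; the one step between them, a 5.8-fold higher number from compound 1 to compound 2 (0.76 log units; beyond the scatter), is nitro in place of bromo on an aromatic carbon.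

Compound 3 `O=C(/C=C/c1cccc(OCc2ccccc2)c1)c1ccc(Cl)cc1` is not yet measured. It differs from compound 1 as follows: chloro in place of bromo on an aromatic carbon. Going by the values given here, no measured step swaps one halogen for another; the only step in hand, from compound 1 to compound 2, replaces bromo with a group of a different kind, so it bears on the new step only loosely. With a halogen-for-halogen change at the same place, the expectation is a small step at most, a 1.2-fold higher number from compound 1 to compound 3 (0.09 log units; within the scatter), and a move beyond the scatter is not expected. For compound 3 the estimated value in this assay is 8000 nM, with a range from 3000 nM to 22000 nM.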

Compound 3, half-maximal inhibitory concentration: 20000 nM
The estimate for compound 3 lay 2.5-fold (0.40 log units) below the measured number; the measured number falls inside the stated range.
By their numbers in this assay, from the lowest: compound 1; then compounds 3 and 2 (each within the scatter of the next).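

In this assay the halogen at this place is not interchangeable: the swap of bromo for chloro gives a modest step beyond the scatter (a 3.1-fold higher number from compound 1 to compound 3 (0.49 log units; beyond the scatter)), so the change from 4-bromophenyl to 4-chlorophenyl counts as a real change in this series, even though only one atom differs. For the compounds shown here, the chloro and nitro groups, by contrast, are not separated at this place (a 1.9-fold lower number from compound 2 to compound 3 (0.28 log units; within the scatter)), which leaves bromo as the only one of the three groups that stands apart and compound 1 as the most active of the three compounds in this assay. Nothing at hand bears on why bromo and chloro differ here, and the step remains an observation without a stated cause.

Open questions remain at the same place: whether fluoro, iodo, an amine, a methoxy group or plain hydrogen would fall with bromo or with the chloro and nitro pair. Also open, from the compounds shown here alone, is whether the step from chloro to bromo would hold if the benzyloxy group on the other side of the shared core were replaced, for example by a hydroxyl group.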